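This account rests on a few compounds, and the source may have more. Where it says the series, first, only, none or still open, it means among the compounds named here.

In an ADME assay on CCRF-CEM cells (Homo sapiens) for cytotoxicity (on this read-out lower numbers stand for higher toxicity in this test and higher numbers for lower toxicity in this test), three compounds have so far been examined. Compound 1 `COC(=O)[C@H](CO)NC(=O)c1cnc2c(C)cccc2c1Cl` gives only a limit, > 100 uM. Compound 2 `COC(=O)[C@H](CO)NC(=O)c1cnc2cc(C)ccc2c1Cl`, which shares its core, gives 59.6 uM. Compound 3 `O=C(NCCO)c1c[nH]c2ccc(Oc3ccccc3)cc2c1=O`, built on a different core, likewise gives only a limit, > 100 uM. Compound 3 therefore stands at the limit of > 100 uM in this assay, at which 2 of the 3 values shown sit, so its exact place among the three cannot be fixed. Compound 4 `O=C(NCCO)c1c[nH]c2ccc(Cl)cc2c1=O` differs from it in one place: chloro in place of phenoxy on an aromatic carbon. Among the compounds with values here, no measured pair mirrors this change, so the size of the step is not known from the data; in this assay a step of no more than the usual scatter, in either direction, is expected. Compound 4 is estimated at 100 uM, within 40 uM to 300 uM. The step this estimate means is expected to be a number no higher from compound 3 to compound 4 (the limit leaves the size open).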

Compound 4, half-maximal toxic concentration: > 100 uM
Compound 4: a limit, no number (the forecaster's own chance of this, stated with the estimate: 55%); the middle value sits exactly at the limit.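

Compound 3 and compound 4 each give only a limit in this assay, so no step can be read between them: the limit of > 100 uM in this assay, at which 3 of the 4 values shown sit. Left open is what chloro in place of phenoxy does to toxicity in this test.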